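A few compounds are considered here, and "the series" means these few. Any claim that something is new, unique, unknown or untested is made for them only; others in the source may bear on it.

Compounds measured in a functional assay on K562 cells (Homo sapiens) for antiproliferative activity, read by trypan blue exclusion, with a stated time of 48 h, tested at 10 uM; on this read-out higher numbers stand for more inhibition of growth at the one concentration tested and lower numbers for less inhibition of growth:
- Compound 1 `NC(=O)c1cc(Br)ccc1NC(=O)/C=C/c1ccccc1`: 62.4%
- Compound 2 `NC(=O)c1cc(Cl)ccc1NC(=O)/C=C/c1cccc(Br)c1`: 27%
- Compound 3 `NC(=O)c1cc(Br)ccc1NC(=O)/C=C/c1ccc(Cl)cc1`: 22%

Compound 3, at 22%, lies within the scatter of compound 2, at 27%. Both numbers are far from that of compound 1, at 62.4%.

The next compound to consider is compound 4 `NC(=O)c1cc(Br)ccc1NC(=O)/C=C/c1cccc(Br)c1`. The change is 3-bromophenyl in place of 4-chlorophenyl on a double-bonded chain carbon bound to a double-bonded chain carbon.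

Among the compounds with values here, only one measured step bears directly on this part of the molecule. It is the large step of a number 40.4 percentage points lower from compound 1 to compound 3 (beyond the scatter), where chloro replaces hydrogen on an aromatic carbon. It shows that a single change on this phenyl group can matter a great deal in this assay.

The closest guide is compound 2, which already carries the 3-bromophenyl group and gives 27%. It differs from compound 4 by having chloro instead of bromo on the shared core. On that evidence, no change beyond the scatter is expected here, although the large drop seen for compound 3 leaves some room for a higher number.

The expected step is a number 6 percentage points higher from compound 3 to compound 4 (within the scatter). For compound 4 the estimated value is 28%, with an expected range from 12% to 48%.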

Compound 4, percent growth inhibition at one concentration: 45.9%
For compound 4 the middle estimate is 17.9 percentage points below the measured one; low and high end bracket the measured number.
By their numbers in this assay, from the lowest: compounds 3 and 2 (each within the scatter of the next); then compound 4; then compound 1.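

Replacing 4-chlorophenyl with 3-bromophenyl gives a number 23.9 percentage points higher from compound 3 to compound 4 (beyond the scatter) in this assay, so these two halogen-bearing phenyl groups are not interchangeable here, although this single swap alters both the halogen and its place on the ring. Within the data shown here, the halogen on the shared core counts as well: bromo in place of chloro on that aromatic carbon, with the 3-bromophenyl group held constant, gives a number 18.9 percentage points higher from compound 2 to compound 4 (beyond the scatter), something the earlier compounds could not show. Adding bromo to the plain phenyl group still gives a number 16.5 percentage points lower from compound 1 to compound 4 (beyond the scatter), so a halogen on this phenyl group goes with a lower number in both compounds compared with compound 1 on the bromo core, the other case being a number 40.4 percentage points lower from compound 1 to compound 3 (beyond the scatter).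

No measured evidence is available to explain these differences. The compounds shown do not separate the contribution of the halogen from that of its place on the phenyl group, and they leave open how an amine or a carboxylic acid on that group would fare.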